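The source may hold more compounds than are shown below. What is called first, only, known or untested is meant among the compounds shown, and "the series" means these compounds.

Measured so far in a functional assay on brain (Rattus norvegicus, strain Wistar) for inhibition; on this read-out lower numbers stand for stronger inhibition and higher numbers for weaker inhibition

Compound 1 `Cc1ccc(-c2c(C)[nH]c(=O)n2C)cc1` gives 85300 nM
Compound 2 `Cc1[nH]c(=O)n(C)c1-c1ccc(OC(C)C)cc1` gives 20400 nM

Compound 2 (20400 nM) has the lower of the two numbers, which makes it the stronger inhibitor of this pair. The next compound, compound 3 `Cc1[nH]c(=O)n(C)c1-c1ccc(OCc2ccccc2)cc1`, keeps the shared core and changes one group, with benzyl in place of isopropyl on an oxygen on an aromatic ring.

Within the data shown here, only one measured step bears on this change: a 4.2-fold lower number from compound 1 to compound 2 (0.62 log units; beyond the scatter) when isopropoxy took the place of methyl on an aromatic carbon. That modest step lies beyond the scatter and points towards a lower number. Among the measured compounds shown here, it is a single step, however, so it shows no trend, and no compound with a benzyl group has been measured yet. A further modest fall is therefore expected, with real uncertainty in both size and direction. The estimate is a 2.3-fold lower number from compound 2 to compound 3 (0.36 log units; beyond the scatter) in this assay as the expected step. The expected value for compound 3 is 9000 nM (2500 nM to 30000 nM).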

Compound 3, half-maximal inhibitory concentration: 6700 nM
Compound 3: the middle estimate sits 1.3-fold (0.13 log units) above what was measured; low and high end bracket the measured number.
By their numbers in this assay, from the lowest: compound 3; then compound 2; then compound 1.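

In this assay, keeping the oxygen and replacing isopropyl with benzyl gives a 3.0-fold lower number from compound 2 to compound 3 (0.48 log units; beyond the scatter) and so brings the strongest inhibition of the three compounds. This shows that the number responds to the group carried on the oxygen, not merely to having an oxygen-linked group on the aromatic ring. Among the compounds shown, the number has now fallen twice beyond the scatter as the group at this place has grown, with none going against that trend, but no measurement here explains the change.

The compounds shown cannot separate the effect of benzyl's aromatic ring from that of its larger count of heavy atoms, a question that a straight butyl chain or a cyclohexylmethyl group on the oxygen could address. On these data alone, it also remains open how the number would respond to a chlorine or methoxy group on the benzyl ring, or to an amine at the end of a chain on the oxygen.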